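Chloro in place of cyano on compound 1

The source may hold more compounds than are shown below. What is called first, only, known or untested is meant among the compounds shown, and "the series" means these compounds.

Compound 1 `CC(C)c1ccc(S(C)(=O)=O)cc1C#Cc1cc(C#N)ccc1OCC(=O)O` gives 151 ng.h/mL
Compound 2 `CCCS(=O)(=O)c1ccc(F)c(C#Cc2cc(Cl)ccc2OCC(=O)O)c1` gives 6140 ng.h/mL

In an ADME assay on the whole organism (plasma, strain BALB/c) for pharmacokinetics, with Mus musculus as the target, at a dose of 5 mg/kg by the oral route (a lower number here means less compound in the circulation, a higher number more compound in the circulation at the dose given), compound 1 stands at 151 ng.h/mL as the lower of the two numbers, and compound 2 stands at 6140 ng.h/mL in the same measure. The gap between these two numbers lies beyond the scatter. Compound 3 `CC(C)c1ccc(S(C)(=O)=O)cc1C#Cc1cc(Cl)ccc1OCC(=O)O` keeps the core of compound 1 and carries one change chloro in place of cyano on an aromatic carbon with chloro in place of cyano on an aromatic carbon. Among the measured compounds shown here, no measured pair shows this change alone. Compound 2 also carries chloro and reaches 6140 ng.h/mL but differs elsewhere too, so a rise beyond the scatter in this assay is expected, smaller than the whole gap. The expected step is a 6.6-fold higher number from compound 1 to compound 3 (0.82 log units; beyond the scatter) upward. Compound 3 is estimated at 1000 ng.h/mL with an expected range from 250 ng.h/mL to 4000 ng.h/mL overall.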

Compound 3, area under the concentration-time curve: 2650 ng.h/mL
The estimate for compound 3 lay 2.7-fold (0.42 log units) below the measured number; low and high end bracket the measured number.
By their numbers in this assay, from the lowest: compound 1; then compound 3; then compound 2.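

In this assay, chloro in place of cyano, on the aromatic carbon para to a carboxymethoxy group, gives an 18-fold higher number from compound 1 to compound 3 (1.24 log units; beyond the scatter), a large step beyond the scatter. This pair isolates the change, so the rise belongs to this one position with the rest of compound 1 held unchanged. Nothing measured here accounts for the size of the step. From the compounds shown here alone, whether bromo, methyl or methoxy on the same aromatic carbon would give a number like that of compound 3 remains open.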